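Trading a Methoxy for a Methyl in the Side Chain

A few compounds are considered here, and "the series" means these few. Any claim that something is new, unique, unknown or untested is made for them only; others in the source may bear on it.

Compound 3 `COCCOc1cc(C)c(-c2cccc(COc3ccc(OCC(=O)O)c(F)c3)c2)c(C)c1` carries the highest number of the three compounds measured in a physicochemical assay for lipophilicity, using the shake flask method, in phosphate buffer, measured as octanol-water partition, with a stated time of 24 h, at pH 7.4, tested at 100 uM; on this read-out lower numbers stand for lower lipophilicity and higher numbers for higher lipophilicity. In this assay compound 3 gives 3.15, with compound 1 `Cc1cc(OCCCO)cc(C)c1-c1cccc(COc2ccc(OCC(=O)O)c(F)c2)c1` nearest at 2.73 and compound 2 `Cc1cc(OCCCS(C)(=O)=O)ccc1-c1cccc(COc2ccc(OCC(=O)O)c(F)c2)c1` furthest at 1.63. Compound 4 `CCCOc1cc(C)c(-c2cccc(COc3ccc(OCC(=O)O)c(F)c3)c2)c(C)c1` has not yet been measured; it differs from compound 3 by methyl in place of methoxy on a saturated chain carbon, two bonds along the chain from an oxygen on an aromatic ring. Among the compounds with values here, the one measured step at this same place on the chain, a number 0.42 log units higher from compound 1 to compound 3 (beyond the scatter), removed a hydrogen-bond donor and raised the number modestly. The step to compound 4 removes the remaining hydrogen-bond acceptor of that chain, and the measured pattern suggests the number should rise again, beyond the scatter, by an amount on the order of that earlier step or somewhat larger. Compound 4 is therefore expected to reach 3.85, in the range 3.45 to 4.3, which means an estimated step of a number 0.70 log units higher from compound 3 to compound 4 (beyond the scatter).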

Compound 4, distribution coefficient: 3.64
Compound 4: the middle estimate sits 0.21 log units above what was measured; the range from low to high includes it.
By their numbers in this assay, from the lowest: compound 2; then compound 1; then compound 3; then compound 4.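

In this assay, putting methyl in place of methoxy on a saturated chain carbon, two bonds along the chain from an oxygen on an aromatic ring, gave a number 0.49 log units higher from compound 3 to compound 4 (beyond the scatter), so the number at this place on the chain had not finished moving with compound 3. Hydrogen in place of hydroxy, three bonds along the chain from the same oxygen, gave a number 0.91 log units higher from compound 1 to compound 4 (beyond the scatter), and across compound 1, compound 3 and compound 4 each change at the chain end raised the number, with none of these three going against that order. Nothing available here accounts for the size of either step.

The compounds shown leave open whether a longer chain such as butoxy would raise the number further. They also leave open where an amine at the same place would fall.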